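Replacing thiophen-2-yl with 5-methylfuran-2-yl: compound 2 to compound 3

A few compounds are considered here, and "the series" means these few. Any claim that something is new, unique, unknown or untested is made for them only; others in the source may bear on it.

Compound 1 `Nc1ccc(F)cc1NC(=O)C1(S(=O)(=O)c2ccc(Oc3ccc(OC(F)(F)F)cc3)cc2)CCC2(CCNCC2)C1` gives > 15000 nM
Compound 2 `Nc1ccc(-c2cccs2)cc1NC(=O)C1(S(=O)(=O)c2ccc(Oc3ccc(OC(F)(F)F)cc3)cc2)CCC2(CCNCC2)C1` gives 900 nM

In a functional assay on blood (Homo sapiens), with a stated time of 60 min, in the presence of a further agent that is not named here (on this read-out higher numbers stand for an effect only at larger amounts of compound and lower numbers for an effect already at smaller amounts), compound 1 has > 15000 nM as a limit and not a number. Compound 2 stands at 900 nM as the only actual number shown so far. The difference 5-methylfuran-2-yl in place of thiophen-2-yl on an aromatic carbon leads to compound 3 `Cc1ccc(-c2ccc(N)c(NC(=O)C3(S(=O)(=O)c4ccc(Oc5ccc(OC(F)(F)F)cc5)cc4)CCC4(CCNCC4)C3)c2)o1` and puts 5-methylfuran-2-yl in place of thiophen-2-yl on an aromatic carbon, para to an amino group. Among the compounds with values here, only one measured step bears on this, the large at least 16-fold lower number from compound 1 to compound 2 (1.22 log units; beyond the scatter) with thiophen-2-yl in place of fluoro. That step replaced fluoro with a ring, whereas here one five-membered aromatic ring replaces another, so no step beyond the scatter is expected in this assay and no clear direction. The expected change is a 1.1-fold lower number from compound 2 to compound 3 (0.05 log units; within the scatter) and would lie within the scatter. Compound 3 is estimated at 800 nM with an expected range from 300 nM to 2500 nM.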

Compound 3, half-maximal effective concentration: > 15000 nM
Compound 3: a limit, no number; the forecaster's own chance of this, stated with the estimate: 8%; middle value at least 18-fold (1.27 log units) from the limit.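

In this assay compound 3 gives > 15000 nM, which is a limit and not a number. The position para to the amino group therefore does not accept every five-membered aromatic ring with one hetero atom: the gain of an at least 16-fold lower number from compound 1 to compound 2 (1.22 log units; beyond the scatter) gives way to an at least 16-fold higher number from compound 2 to compound 3 (1.22 log units; beyond the scatter) when 5-methylfuran-2-yl takes the place of thiophen-2-yl. The step between compound 1 and compound 3 cannot be read, because both compounds sit at the same limit: the limit of > 15000 nM in this assay, at which 2 of the 3 values shown sit.

Two things change at once from compound 2 to compound 3, the ring oxygen in place of sulfur and the added methyl, so the compounds shown do not tell which of them accounts for the step. Unsubstituted furan-2-yl and 5-methylthiophen-2-yl at this carbon would each separate the two.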